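The source may report more compounds than this note shows. Statements on the series, on what has been measured and on what is new or still open speak of the compounds shown alone.

Measured so far:

Compound 1, `O=C(N/N=C1\C(=O)Nc2ccccc21)Nc1ccccc1`, in an ADME assay on RD cells (Homo sapiens) for cytotoxicity; on this read-out lower numbers stand for higher toxicity in this test and higher numbers for lower toxicity in this test: > 25000 nM
Compound 2, `O=C1/C(=N\NC(=S)Nc2ccccc2)c2ccccc2N1c1ccccc1`, in this assay: > 25000 nM

Both of these values are limits of the assay rather than numbers. For compound 1 the value > 25000 nM is a limit. For compound 2 the value > 25000 nM is likewise a limit. For the measured compounds named here, compound 2 therefore stands at the limit of > 25000 nM in this assay, at which 2 of the 2 values shown sit, with no numeric reading of its own, and the same is true of the one other value shown. Going by the values given here, no step between measured compounds is available, so the two values show only that neither compound reached a half-maximal cytotoxic concentration within the tested window.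

Compound 3, `O=C1/C(=N\NC(=S)Nc2ccccc2)c2ccccc2N1Cc1ccccc1`, is not yet measured. It differs from compound 2 as follows: benzyl in place of phenyl on an amide-type nitrogen in a ring.

With both measured compounds sitting at the limit, no step beyond the usual scatter is expected from compound 2 to compound 3; the expectation is no change that would be visible in this assay. The expected step is a step that the limit leaves unreadable from compound 2 to compound 3. For compound 3 the estimate is 30000 nM, with a range from 12000 nM to 80000 nM, and most likely the assay again reports only a limit.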

Compound 3, half-maximal cytotoxic concentration: > 25000 nM
Compound 3: no number, only a limit; the forecaster's own chance of this, stated with the estimate: 75%; the middle value does not contradict the limit.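

No step can be read from compound 2 to compound 3, as both values are limits rather than numbers: the limit of > 25000 nM in this assay, at which 3 of the 3 values shown sit.

The compounds shown leave open whether benzyl in place of phenyl on the amide-type nitrogen in a ring changes the result in this assay at all, and at what concentration any of the three compounds would reach a half-maximal cytotoxic effect.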